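The source may hold more compounds than are shown below. What is called first, only, known or untested is meant among the compounds shown, and "the series" means these compounds.

Working notes on the series.

Compound 1 `O=C1/C(=C/c2ccccc2)CCc2ccccc21` in a functional assay on MOLT-4 cells (Homo sapiens) for inhibition (a lower number here means a stronger inhibitor, a higher number a weaker inhibitor), gives 32400 nM. Compound 2 `O=C1/C(=C/c2ccc(F)cc2)CCc2ccccc21` carries one change against it, (fluoro in place of hydrogen on an aromatic carbon), and in this assay compound 2 gives 41200 nM; the step is a 1.3-fold higher number from compound 1 to compound 2 (0.10 log units; within the scatter), so the two numbers are not told apart. Compound 3 `O=C1CCCCC/C1=C\c1ccccc1` has a different core; how the two cores differ is not broken down here. In this assay compound 3 gives 215000 nM, the highest number of the three and beyond the scatter from both compound 1 and compound 2, so compound 3 is the weakest inhibitor measured so far.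

Compound 4 `O=C1CCCCC/C1=C\c1ccc(F)cc1` has not been measured. Against compound 3 it carries fluoro in place of hydrogen on an aromatic carbon. Within the data shown here, this is the same kind of change as the one from compound 1 to compound 2, though not the same: in compound 4 the entering fluoro stands para to a group of 9 heavy atoms, whereas in compound 2 it stands para to a large group. Since the step from compound 1 to compound 2 stayed within the scatter, the step to compound 4 is expected to be small as well, about a 1.2-fold higher number from compound 3 to compound 4 (0.08 log units; within the scatter). Compound 4 is therefore estimated at 260000 nM, with a range of 120000 nM to 550000 nM.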

Compound 4, half-maximal inhibitory concentration: 250000 nM
Beside the measured number, compound 4's estimate is 1.0-fold (0.02 log units) above it, within the range that was stated.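

On the core of compound 3, fluoro in place of hydrogen on an aromatic carbon gives in this assay a 1.2-fold higher number from compound 3 to compound 4 (0.07 log units; within the scatter) and so leaves the two numbers not told apart. Set beside the earlier step, the change behaves alike on both cores, with no difference that can be told apart: the same change on two cores in this assay, a 1.3-fold higher number (0.10 log units; within the scatter) from compound 1 to compound 2 and a 1.2-fold higher number (0.07 log units; within the scatter) from compound 3 to compound 4, 1.1-fold (0.04 log units) apart, within the scatter of two such steps. Among these compounds, this shows only that the change can be carried between these two cores without a step beyond the scatter; it does not show that fluoro has no effect at all, as a small effect could lie within the scatter, and two cores say nothing about a third core or about another assay.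

The compounds shown leave open whether a different group on the same aromatic carbon, such as methoxy, trifluoromethyl, an amine or a carboxylic acid, would give a step beyond the scatter on either core. Also open, going by these compounds, is whether such a group would behave alike on the two cores, as fluoro does here.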